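A few compounds are considered here, and "the series" means these few. Any claim that something is new, unique, unknown or untested is made for them only; others in the source may bear on it.

Among the compounds with values here, in an ADME assay on LLC-PK1 cells (Sus scrofa) for permeability, with a stated time of 3 h, tested at 1 uM (a higher number here means that the compound crosses the layer faster, a lower number that the compound crosses the layer more slowly), three compounds have numbers so far. Compound 1 `O=C(O)CNC(=O)c1c(O)c2ccc(Cl)cc2n(Cc2ccc(C(F)(F)F)cc2)c1=O` gives 16 10^-6 cm/s, compound 2 `O=C(O)CNC(=O)c1c(O)c2c(n(Cc3ccc(C(F)(F)F)cc3)c1=O)COCC2` gives 7.3 10^-6 cm/s, and compound 3 `O=C(O)CNC(=O)c1c(O)c2c(n(Cc3ccc(Cl)cc3)c1=O)CCOC2` gives 3.6 10^-6 cm/s. Compound 3 therefore stands lowest of the three, and its gaps to both of the others lie beyond the scatter.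

Compound 4 `O=C(O)CNC(=O)c1c(O)c2c(n(Cc3ccc(C(F)(F)F)nc3)c1=O)CCOC2` has not yet been measured. It differs from compound 3 in one place, with 6-(trifluoromethyl)pyridin-3-yl in place of 4-chlorophenyl on a saturated chain carbon bound to an aromatic nitrogen. Within the data shown here, no measured pair isolates this change, since compound 1 and compound 2 also differ from compound 3 in the core. The closest guide is compound 2, which carries a trifluoromethyl group and reads 7.3 10^-6 cm/s, but its aromatic ring holds no nitrogen, so it offers only a loose hint. In this assay, only a small upward step, not beyond the scatter, is expected. The estimate amounts to an expected 1.3-fold higher number from compound 3 to compound 4 (0.10 log units; within the scatter). For compound 4 the estimated value is 4.5 10^-6 cm/s, with an expected range from 2 10^-6 cm/s to 10 10^-6 cm/s.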

Compound 4, apparent permeability: < 1.7 10^-6 cm/s
Compound 4 gave a limit, no number (the forecaster's own chance of this, stated with the estimate: 3%); at least 2.6-fold (0.42 log units) between middle value and limit.
By their numbers in this assay, from the lowest: compound 3; then compound 2; then compound 1. At a limit, below all of these: compound 4.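

In this assay, within the data shown here, replacing 4-chlorophenyl with 6-(trifluoromethyl)pyridin-3-yl on a saturated chain carbon bound to an aromatic nitrogen gives an at least 2.1-fold lower number from compound 3 to compound 4 (0.32 log units; beyond the scatter), so the group at this position alone can move the reading beyond the scatter, something the earlier compounds could not show, as they held no measured step in one place. For compound 4, the reading of < 1.7 10^-6 cm/s is a limit of the assay and not a number. The step therefore has a lower bound but no fixed size, and the direction is downward, whereas the trifluoromethyl group of compound 2 had offered only a loose hint of the opposite direction; the size rests on a limit alone: the limit of < 1.7 10^-6 cm/s in this assay, at which 1 of the 4 values shown sits.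

The compounds shown do not separate the two differences within the entering group, the ring nitrogen and the trifluoromethyl group in place of chlorine, so it stays open which of them carries the step; a chloropyridinyl group, which has the ring nitrogen and keeps the chlorine, would tell them apart on this core. On these data alone, whether a smaller group on the same carbon, such as a methoxy-substituted phenyl or a plain pyridinyl, would keep the reading above the limit also remains open.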